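Shortening the decyl chain on a thiocarbamate phosphate

The compounds below may be only part of what the source reports. "The series", "measured", "known", "first", "only" and "open" are said of these compounds alone.

Compound 1 `CCCCCCCCCCOP(=O)(O)OCCSC(=S)N1CCCC1`: 56100 nM
Compound 2 `CCCOP(=O)(O)OCCSC(=S)N1CCCCCC1`: > 100000 nM
Compound 3 `CCCCCCCCCCOP(=O)(O)OCCSC(=S)N1CCN(C)CC1`: 80000 nM

In a functional assay on PC-3 cells (Homo sapiens) for inhibition, read by MTT assay, with stated times of 18 h and 4 h (a higher number here means a weaker inhibitor, a lower number a stronger inhibitor), compound 1 gives 56100 nM, the lowest of the two numbers recorded. Its nearest neighbour is compound 3, and the step of a 1.4-fold higher number from compound 1 to compound 3 (0.15 log units; within the scatter) leaves the two indistinguishable. Compound 2 gives only a limit, > 100000 nM, so its value is not a number; one of the three results sits at the limit of > 100000 nM in this assay, at which 1 of the 3 values shown sits.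

Compound 4 `CCCCCCOP(=O)(O)OCCSC(=S)N1CCCC1` has not yet been measured. It differs from compound 1 in one place: hydrogen in place of butyl on a saturated chain carbon, six bonds along the chain from an oxygen on an unsaturated carbon. Among the compounds with values here, no measured pair isolates this change. Compound 2 carries a shorter chain than compound 1 but also a different ring on the thiocarbonyl carbon, so its limit cannot be laid to the chain alone. Within the data shown here, with no step to lean on, compound 4 is expected near compound 1 or somewhat weaker, with a real chance of reaching the limit; the expected step is a 1.6-fold higher number from compound 1 to compound 4 (0.21 log units; within the scatter). The estimate for compound 4 in this assay is 90000 nM, within 40000 nM to 200000 nM.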

Compound 4, half-maximal inhibitory concentration: > 100000 nM
Compound 4: no number, only a limit; the forecaster's own chance of this, stated with the estimate: 40%; middle value at least 1.1-fold (0.04 log units) away from the limit.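

Within the data shown here, compound 4 keeps the ring of compound 1 and changes only the chain, so this is the first pair to isolate hydrogen in place of butyl on this saturated chain carbon in this assay: an at least 1.7-fold higher number from compound 1 to compound 4 (0.25 log units; that floor lies within the scatter). The value of compound 4 is a limit and not a number, so the step is only a floor, and it shows no loss beyond the scatter while leaving the true size of the change unknown. Compound 4 now shares that limit with compound 2: the limit of > 100000 nM in this assay, at which 2 of the 4 values shown sit.

As far as these compounds go, it remains open how an octyl or a dodecyl chain on the core of compound 1 would read in this assay. Also open, from the compounds shown here alone, is how much of the limit of compound 2 belongs to its chain and how much to its ring.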